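Swapping a Methoxyphenyl for a Methylphenyl on the Shared Core

This account rests on a few compounds, and the source may have more. Where it says the series, first, only, none or still open, it means among the compounds named here.

The compounds measured so far in a functional assay on U-251 cells (Homo sapiens) for antiproliferative activity, read by MTT assay, with a stated time of 48 h; a lower number here means a stronger inhibitor, a higher number a weaker inhibitor:
compound 1 `COc1cccc(-c2nc3cccc(-c4cc(OC)c(OC)c(OC)c4)c3o2)c1` gives > 25000 nM, a limit of the assay rather than a number.
compound 2 `COc1cc(-c2cccc3nc(-c4cccc(Br)c4)oc23)cc(OC)c1OC` gives 6800 nM.
compound 3 `COc1cc(-c2cccc3nc(-c4ccc(Br)cc4)oc23)cc(OC)c1OC` gives > 25000 nM, again a limit and not a number.

Compound 1 thus stands at the limit, and the evidence is thin: of the three values shown, two are limits (the limit of > 25000 nM in this assay, at which 2 of the 3 values shown sit). Only compound 2 gives a readable number. The step of an at least 3.6-fold lower number from compound 1 to compound 2 (0.56 log units; beyond the scatter), bromo in place of methoxy, is at least modest and goes toward stronger inhibition. The step of an at least 3.6-fold higher number from compound 2 to compound 3 (0.56 log units; beyond the scatter), 4-bromophenyl in place of 3-bromophenyl, is at least modest and goes the other way, back to the limit. The step that the two limits leave unreadable from compound 1 to compound 3 cannot be sized from two limits.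

Compound 4 `COc1cc(-c2cccc3nc(-c4ccc(C)cc4)oc23)cc(OC)c1OC` is the unmeasured partner of compound 1. The change is 4-methylphenyl in place of 3-methoxyphenyl on an aromatic carbon. Its methyl sits on the 4-methylphenyl, as the bromo does on the 4-bromophenyl of compound 3, and both compound 1 and compound 3 sit at the limit (the limit of > 25000 nM in this assay, at which 2 of the 3 values shown sit). Going by the values given here, no measured step supports a move beyond the scatter for this change. Compound 4 is therefore expected to remain weak, most likely at the limit again, an estimated 30000 nM with a range from 8000 nM to 100000 nM. The expected step is a step that the limit leaves unreadable from compound 1 to compound 4.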

Compound 4, half-maximal inhibitory concentration: 3200 nM
The estimate for compound 4 lay 9.4-fold (0.97 log units) above the measured number; the measured number lies below the stated range.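

Compound 4 shows that a 4-substituted phenyl on this carbon of the shared core, next to the ring nitrogen and next to the ring oxygen, is not weak as such in this assay: methyl in place of bromo gives an at least 7.8-fold lower number from compound 3 to compound 4 (0.89 log units; beyond the scatter), so the group on the ring matters and not only its place. Replacing the 3-methoxyphenyl also gives an at least 7.8-fold lower number from compound 1 to compound 4 (0.89 log units; beyond the scatter), and the comparison with the earlier readable compound gives a 2.1-fold lower number from compound 2 to compound 4 (0.33 log units; beyond the scatter), a modest step that makes compound 4 the strongest of the four. Compound 1 and compound 3 each stand at a limit and not at a number, so the two steps that start from them give only a minimum size: the limit of > 25000 nM in this assay, at which 2 of the 4 values shown sit.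

From the compounds shown here alone, it remains open whether 3-methylphenyl would match or beat 4-methylphenyl, and what 4-methoxyphenyl would give, so the effects of the group and of its place on the ring are not yet fully separated. Also open, going by these compounds, is how this position would respond to an amine, a carboxylic acid or a longer chain such as ethyl on the phenyl ring.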